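The source may report more compounds than this note shows. Statements on the series, on what has been measured and on what is new or still open speak of the compounds shown alone.

Within the data shown here, in an in vitro ADME assay on microsomes from liver (Mus musculus) for pharmacokinetics, read by LC-MS, with a stated time of 10 min, tested at 1 uM (on this read-out lower numbers stand for slow clearance and higher numbers for fast clearance), compound 1 `Cc1ccc(NC(=O)[C@H]2CN(C)C[C@@H]2c2ccc(/C=C/C(=O)Nc3ccccc3N)cc2)cc1` gives 62 mL/min/kg and compound 2 `CN1C[C@H](C(=O)Nc2ccc(C#N)cc2)[C@@H](c2ccc(/C=C/C(=O)Nc3ccccc3N)cc2)C1` gives 35 mL/min/kg, so compound 2 stands within the scatter of the only other measured number. Compound 3 `CN1C[C@H](C(=O)Nc2ccc(Br)cc2)[C@@H](c2ccc(/C=C/C(=O)Nc3ccccc3N)cc2)C1` carries bromo in place of cyano on an aromatic carbon, para to a large group: bromo in place of cyano on an aromatic carbon. Among the measured compounds shown here, the one measured step at this place, a 1.8-fold lower number from compound 1 to compound 2 (0.25 log units; within the scatter), put cyano in place of methyl and stayed within the scatter. A step beyond the scatter is therefore not expected, and the expected step is a 1.3-fold higher number from compound 2 to compound 3 (0.11 log units; within the scatter). The estimate for compound 3 is 45 mL/min/kg, with an expected range from 22 mL/min/kg to 85 mL/min/kg.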

Compound 3, clearance: 16 mL/min/kg
Estimate against measurement, compound 3: 2.8-fold (0.45 log units) above, and the stated range ends above it.
By their numbers in this assay, from the lowest: compound 3; then compounds 2 and 1 (each within the scatter of the next).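

At this place on an aromatic carbon, para to a large group, the change now reaches beyond the scatter in this assay: bromo in place of cyano gives a 2.2-fold lower number from compound 2 to compound 3 (0.34 log units; beyond the scatter) and bromo in place of methyl gives a 3.9-fold lower number from compound 1 to compound 3 (0.59 log units; beyond the scatter) at the same place. Bromo thus stands apart from both cyano and methyl, which remain within the scatter of each other. Nothing measured here accounts for this result.

The compounds shown leave open whether chloro, methoxy or an amine at this place would read like bromo, and whether bromo would have the same effect on another position of this ring.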